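This account rests on a few compounds, and the source may have more. Where it says the series, first, only, none or still open, it means among the compounds named here.

Compound 3 `CC(C)(C)c1ccc(/C(=C/C(=O)Nc2ccc3c(c2)OCCO3)c2ccncc2)cc1` gives 44 nM in a functional assay on CHO cells for inhibition of transient receptor potential cation channel subfamily V member 1 (Homo sapiens) (a lower number here means a stronger inhibitor, a higher number a weaker inhibitor), the lowest of the three numbers recorded. For the measured compounds named here, its closest companion is compound 2 `CC(C)(C)c1ccc(/C(=C/C(=O)Nc2ccc3c(c2)OCCO3)c2cccnc2)cc1`, which gives 78 nM; the single one-point step among the measured compounds, a 1.8-fold lower number from compound 2 to compound 3 (0.25 log units; within the scatter), lies within the scatter. Compound 1 `CC(C)(C)c1ccc(CCC(=O)Nc2ccc3c(c2)OCCO3)cc1`, with a saturated chain carrying no extra group, gives 150 nM. Compound 4 `CC(C)C/C(=C\C(=O)Nc1ccc2c(c1)OCCO2)c1ccc(C(C)(C)C)cc1` differs from compound 3 in one place: isobutyl in place of pyridin-4-yl on a double-bonded chain carbon bound to an aromatic carbon and a double-bonded chain carbon. Going by the values given here, no measured step bears on exchanging pyridin-4-yl for isobutyl; the only precedent swaps one pyridyl for another and barely moves the number, while compound 1 shows only that dropping the group altogether gives a higher number. For compound 4 a modest rise is expected, estimated as a 2.3-fold higher number from compound 3 to compound 4 (0.36 log units; beyond the scatter). Compound 4 is estimated at 100 nM, between 30 nM and 400 nM.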

Compound 4, half-maximal inhibitory concentration: 16 nM
Estimate against measurement, compound 4: 6.3-fold (0.80 log units) above, and the stated range ends above it.
By their numbers in this assay, from the lowest: compound 4; then compounds 3, 2 and 1 (each within the scatter of the next, the first and the last beyond it).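

On the double-bonded chain carbon bound to an aromatic carbon and a double-bonded chain carbon, a pyridyl group proves unnecessary for a low number in this assay: isobutyl, with no ring and no hydrogen-bond acceptor, gives a 2.8-fold lower number from compound 3 to compound 4 (0.44 log units; beyond the scatter) and a 4.9-fold lower number from compound 2 to compound 4 (0.69 log units; beyond the scatter) at this place. For the compounds shown here, the earlier pair had compared only one pyridyl group with another, so this is the first change here that moves the number beyond the scatter. No measured evidence accounts for the gain. From the compounds shown here alone, it remains open how a shorter chain such as methyl, a cyclohexyl ring or an unsubstituted phenyl ring would compare here.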